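Compound 1 to compound 4: the sulfonamide nitrogen

The source may hold more compounds than are shown below. What is called first, only, known or untested is meant among the compounds shown, and "the series" means these compounds.

- compound 1 `Cc1cc(C)nc(NS(=O)(=O)c2ccc(Nc3nncc4ccccc34)cc2)n1`: 7.9 nM
- compound 2 `C(=C/c1ccccc1)\C(=N\Nc1nncc2ccccc12)c1ccccc1`: 2.4 nM
- compound 3 `S=C(NNc1nncc2ccccc12)Nc1ccccc1`: 77 nM

In a functional assay on COLO 205 cells (Homo sapiens) for antiproliferative activity, read by sulforhodamine B assay, with a stated time of 72 h (on this read-out lower numbers stand for stronger inhibition and higher numbers for weaker inhibition), compound 1 gives 7.9 nM, the second highest of the three numbers. Compound 4 `NS(=O)(=O)c1ccc(Nc2nncc3ccccc23)cc1` has hydrogen in place of 4,6-dimethylpyrimidin-2-yl on a sulfonamide nitrogen. Going by the values given here, no measured pair differs in one place only, so the expectation rests on the spread from compound 2 at 2.4 nM to compound 3 at 77 nM. A moderate move toward weaker inhibition is expected, with the estimated step of a 2.5-fold higher number from compound 1 to compound 4 (0.40 log units; beyond the scatter). The estimated value for compound 4 is 20 nM, with an expected range of 4 nM to 100 nM.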

Compound 4, half-maximal inhibitory concentration: 23 nM
Compound 4: the middle estimate sits 1.2-fold (0.06 log units) below what was measured; the measured number falls inside the stated range.
By their numbers in this assay, from the lowest: compound 2; then compound 1; then compound 4; then compound 3.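

In this assay the change from 4,6-dimethylpyrimidin-2-yl to hydrogen on the sulfonamide nitrogen gives a 2.9-fold higher number from compound 1 to compound 4 (0.46 log units; beyond the scatter), the first step read at this position. The step is modest, and compound 4, which lacks the whole group, still gives 23 nM, so the group is not required for activity in this assay. Nothing measured here accounts for the size of this step.

Going by these compounds, whether a methyl or acetyl group on the sulfonamide nitrogen would fall closer to compound 1 or to compound 4 remains open. So does whether a plain phenyl ring would serve in place of 4,6-dimethylpyrimidin-2-yl.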